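The compounds below may be only part of what the source reports. "The series", "measured", "known", "first", "only" and "open" are said of these compounds alone.

Measured so far:
- Compound 1 `Cc1cc(NNC(=O)Nc2cc(Cl)nc(Cl)c2)ncc1C#N` — in a functional assay on CHO cells for antagonist activity at sphingosine 1-phosphate receptor 2 (Homo sapiens), read by scintillation counting and GTPgammaS binding, with a stated time of 4 h, in the presence of a further agent that is not named here (a higher number here means a weaker inhibitor, a lower number a stronger inhibitor), compound 1 gives 7 nM.
- Compound 2 `Cc1cc(CNC(=O)Nc2cc(Cl)nc(Cl)c2)ncc1-c1cn(C)nc1C` — in this assay compound 2 gives 0.77 nM.
- Compound 3 `CCOc1cc(NC(=O)NCc2cc(C)c(-c3cn(C)nc3C)cn2)cc(Cl)n1` — in this assay compound 3 gives 0.32 nM.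

Compound 3 stands lowest of the three numbers. Among the measured compounds shown here, its nearest neighbour is compound 2, from which the single change of ethoxy in place of chloro gave a 2.4-fold lower number from compound 2 to compound 3 (0.38 log units; beyond the scatter). For the measured compounds named here, compound 1, which differs from compound 2 in more than one place, sits far higher; the two values show only that the pair with the pyrazolyl group and the methylene linker come in well below it.

Compound 4 `CCOc1cc(NC(=O)NCc2cc(C)c(N3CC(C)OC(C)C3)cn2)cc(Cl)n1` is the next step: 2,6-dimethylmorpholin-4-yl in place of 1,3-dimethyl-1H-pyrazol-4-yl on an aromatic carbon. Going by the values given here, no measured pair in this set changes the group at that position, so no step bears directly on it; the only guide is that compounds 2 and 3, both carrying the pyrazolyl group, hold the two lowest values. Replacing an aromatic ring with a saturated one at that place is an untested move here, and the expectation is therefore a modest rise in this assay rather than none. Compound 4 is expected to give 1 nM, with a range of 0.3 nM to 4 nM, which means a step of a 3.1-fold higher number from compound 3 to compound 4 (0.49 log units; beyond the scatter).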

Compound 4, half-maximal inhibitory concentration: 105 nM
The estimate for compound 4 lay 110-fold (2.02 log units) below the measured number; the measured number lies above the stated range.
By their numbers in this assay, from the lowest: compound 3; then compound 2; then compound 1; then compound 4.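

In this assay, among the compounds shown here, the place on the six-membered aromatic ring with 1 nitrogen, ortho to a methyl group, turns out to be highly sensitive to what it carries: 2,6-dimethylmorpholin-4-yl in place of 1,3-dimethyl-1H-pyrazol-4-yl gives a 330-fold higher number from compound 3 to compound 4 (2.52 log units; beyond the scatter) as the only measured change at this position. Compounds 2 and 3 both carry the pyrazolyl group and so could not show this, and the new step is far larger than the change on the other side of the urea, the ethoxy for chloro exchange that gives a 2.4-fold lower number from compound 2 to compound 3 (0.38 log units; beyond the scatter) in that same assay. No measurement given here explains the size of this rise.

With a single non-aromatic ring at this place, the compounds shown cannot separate the loss of the five-membered aromatic ring from the presence of the two methyl groups on the morpholine, and an unsubstituted morpholin-4-yl, a piperazin-1-yl or a pyridin-3-yl group there would each bear on that question. From the compounds shown here alone, it also remains open whether the 2,6-dimethylmorpholin-4-yl group would give a similar number with chloro in place of ethoxy.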